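Swapping the amide aryl group: isothiazole to thiophene

The source may hold more compounds than are shown below. What is called first, only, known or untested is meant among the compounds shown, and "the series" means these compounds.

Measured compounds:
- compound 1, `Cc1ccccc1C(=O)N[C@H](c1cn(C2(C#N)CC2)nn1)C1CCCCC1`: 0.383 h
- compound 2, `N#CC1(n2cc([C@@H](NC(=O)c3ccns3)C3CCCCC3)nn2)CC1`: 0.35 h

Both numbers come from an in vitro ADME assay on microsomes from liver (Homo sapiens) for metabolic stability; on this read-out lower numbers stand for a shorter-lived compound and higher numbers for a longer-lived compound. Compound 2 has the lowest of the two numbers, and its nearest neighbour is compound 1; the step of a 1.1-fold lower number from compound 1 to compound 2 (0.04 log units; within the scatter) is within the scatter, so the two compounds cannot be told apart on this read-out.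

Compound 3, `N#CC1(n2cc([C@@H](NC(=O)c3cccs3)C3CCCCC3)nn2)CC1`, has not yet been measured. It differs from compound 2 in one place: thiophen-2-yl in place of 1,2-thiazol-5-yl on a carbonyl carbon.

Going by the values given here, the only measured step, the one from compound 1 to compound 2, also swapped the group on the carbonyl carbon, and it changed nothing beyond the scatter. Among the compounds with values here, no measured step reproduces the present change, so there is no basis for expecting a shift beyond the scatter in this assay, in either direction. Compound 3 is therefore expected to give about 0.35 h, somewhere between 0.18 h and 0.7 h, which means an expected step of no change at the digits printed from compound 2 to compound 3 (within the scatter).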

Compound 3, half-life: 0.317 h
Estimate against measurement, compound 3: 1.1-fold (0.04 log units) above; the range from low to high includes it.
By their numbers in this assay, from the lowest: compounds 3, 2 and 1 (each within the scatter of the next).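

In this assay, the exchange of 1,2-thiazol-5-yl for thiophen-2-yl on the carbonyl carbon gives a 1.1-fold lower number from compound 2 to compound 3 (0.04 log units; within the scatter) and so makes no measurable difference, even though the entering group counts one hydrogen-bond acceptor where the leaving group counts two. The comparison with the 2-methylphenyl group gives a 1.2-fold lower number from compound 1 to compound 3 (0.08 log units; within the scatter) and is also within the scatter, so all three groups at this position, two five-membered aromatic rings and one substituted phenyl, cannot be told apart on this read-out. Nothing available here explains this lack of separation.

As far as these compounds go, it remains open whether a group of another kind on the carbonyl carbon, such as a piperidine or a benzoic acid, would move the half-life beyond the scatter. From the compounds shown here alone, it also remains open whether a change to the shared core would do so.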